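Swapping the aryl group on the alkyne of compound 3

The source may report more compounds than this note shows. Statements on the series, on what has been measured and on what is new or still open speak of the compounds shown alone.

The measured compounds in a functional assay on MCF7 cells (Homo sapiens) for antiproliferative activity, read by MTT assay, with a stated time of 72 h; on this read-out higher numbers stand for weaker inhibition and lower numbers for stronger inhibition:
compound 1 `O=c1[nH]c(=O)n(CCC(CO)CO)cc1-c1ccco1`, compound 1 gives < 10 nM
compound 2 `O=c1[nH]c(=O)n(CCC(CO)CO)cc1-c1cccs1`, compound 2 gives 6000 nM
compound 3 `CC(=O)OCC(CCn1cc(C#Cc2cc(F)cc(F)c2)c(=O)n(C(=O)c2ccccc2)c1=O)COC(C)=O`, compound 3 gives 28900 nM

The value of compound 1 is a limit of the assay, not a number, as described by the limit of < 10 nM in this assay, at which 1 of the 3 values shown sits. Compound 3 gives the highest of the two numbers, meaning the weakest inhibition; compound 2 sits nearer to it with a lower number, and the gap between them lies beyond the scatter.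

Among the measured compounds shown here, the only measured step, an at least 600-fold higher number from compound 1 to compound 2 (2.77 log units; beyond the scatter), concerns the five-membered ring on the shared core. It is a large step, but it lies at a different place from the change considered here.

Compound 4 `CC(=O)OCC(CCn1cc(C#Cc2ccc(Br)cc2)c(=O)n(C(=O)c2ccccc2)c1=O)COC(C)=O` differs from compound 3 by 4-bromophenyl in place of 3,5-difluorophenyl on a triple-bonded carbon. For the measured compounds named here, no measured step touches the group on the alkyne, so there is nothing among the numbers that points in either direction for this change. The expectation for compound 4 is therefore a step of a 1.2-fold lower number from compound 3 to compound 4 (0.06 log units; within the scatter), that is, no change beyond the scatter, with wide uncertainty. Compound 4 is estimated to give 25000 nM, with a range from 5000 nM to 100000 nM.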

Compound 4, half-maximal inhibitory concentration: 28900 nM
The estimate for compound 4 lay 1.2-fold (0.06 log units) below the measured number; low and high end bracket the measured number.
By their numbers in this assay, from the lowest: compound 2; then compounds 3 and 4 (each within the scatter of the next). At a limit, below all of these: compound 1.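

Among the compounds shown here, this is the first measured step that touches the group on the triple-bonded carbon. In this assay, 4-bromophenyl in place of 3,5-difluorophenyl gives no change at the digits printed from compound 3 to compound 4 (within the scatter), so at this position a phenyl ring carrying fluorine and a phenyl ring carrying bromine, at different places on the ring, read alike while the rest of the molecule stays the same. One pair cannot set a rule for this position, and nothing measured here explains why these two groups read alike.

On these data alone, what stays open is how far this tolerance reaches: a phenyl ring carrying an amine or a carboxylic acid, or a longer chain between the triple bond and the ring, could match these two compounds or move well away from them. As far as these compounds go, it is also open whether the same swap would read alike on the core of compound 2, which carries free hydroxyl groups and has a furan or thiophene ring directly on the core in place of the triple bond.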